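A Hydroxy Group Added to a Sphingosine Kinase Binder

The source may report more compounds than this note shows. Statements on the series, on what has been measured and on what is new or still open speak of the compounds shown alone.

Measured compounds:
compound 1, `CCCCC#C[C@@H](O)[C@H](C)N`, 4.85%
compound 2, `CCCCC#C[C@H](O)[C@H](CO)NC(=O)OC(C)(C)C`, reported as "not active" (no number reported), with no number

Going by the values given here, in an assay on CHO cells for inhibition of sphingosine kinase 1 (Homo sapiens), tested at 10 uM (on this read-out lower numbers stand for less inhibition and higher numbers for more inhibition at the one concentration tested (going by the name of the read-out)), compound 1 gives 4.85%, which is the only number recorded here; compound 2 is reported as "not active" (no number reported) with no number, so no step between the two can be counted. Compound 1 therefore stands at a level that is hard to tell apart from no inhibition at all.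

Compound 3, `CCCCC#C[C@@H](O)[C@@H](N)CO`, differs from compound 1 by one change: hydroxy in place of hydrogen on a saturated chain carbon, two bonds along the chain from an amine nitrogen. Because compound 1 sits at 4.85%, there is little room for the number to fall, and nothing measured points to a rise. The expected step of a number 0.2 percentage points higher from compound 1 to compound 3 (within the scatter) is therefore none beyond the usual scatter. Compound 3 is estimated at 5% in this assay, with a likely range from -8% to 20%.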

Compound 3, a percentage reported as inhibition, at one concentration (the size of the read-out at that concentration, not a potency): "not active" (no number reported)
Compound 3: no number reported; no gap can be computed for the estimate.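

Going by these compounds alone, compound 3 is reported as not active, without a number, so no step from compound 1 to compound 3 can be read. The compounds shown leave open whether adding the hydroxy changes the inhibition at all. No other measurement shown here bears on this result.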